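From compound 3 to compound 4: propyl for methoxy

The source may hold more compounds than are shown below. What is called first, only, known or untested is meant among the compounds shown, and "the series" means these compounds.

Three measured compounds share one core. Compound 1 is `CCOC(=O)C1=C(C)NC(=S)NC1c1ccc(O)c(O)c1`, compound 2 is `CCOC(=O)C1=C(C)NC(=S)NC1c1cc(OC)c(O)c(OC)c1` and compound 3 is `CCOC(=O)C1=C(C)NC(=S)NC1c1ccc(OC)cc1`. In a functional assay on U-251 cells (Homo sapiens) for inhibition, read by sulforhodamine B assay, with a stated time of 48 h (a higher number here means a weaker inhibitor of growth, a lower number a stronger inhibitor of growth), compound 3 gives 29 ug/mL, the highest of the three numbers. Compound 1 gives 26.5 ug/mL, within the scatter of compound 3, so no order between the two can be stated. Compound 2 gives 0.77 ug/mL, beyond the scatter from both others and the lowest of the set. Compound 4, `CCCc1ccc(C2NC(=S)NC(C)=C2C(=O)OCC)cc1`, differs from compound 3 in one place: propyl in place of methoxy on an aromatic carbon. Among the measured compounds shown here, no measured pair shows this change, and none of the measured compounds carries a propyl group. The expected step of a 1.2-fold lower number from compound 3 to compound 4 (0.06 log units; within the scatter) is small, with no direction beyond the scatter. Compound 4 is estimated at 25 ug/mL, with a range from 8 ug/mL to 80 ug/mL.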

Compound 4, concentration for 50% growth inhibition: 29.2 ug/mL
For compound 4 the middle estimate is 1.2-fold (0.07 log units) below the measured one; low and high end bracket the measured number.
By their numbers in this assay, from the lowest: compound 2; then compounds 1, 3 and 4 (each within the scatter of the next).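

In this assay, among the compounds shown here, propyl in place of methoxy on this aromatic carbon gives a 1.0-fold higher number from compound 3 to compound 4 (0.00 log units; within the scatter), the only measured pair that differs at this place. Here the two groups are not told apart, even though the hydrogen-bond acceptor and the oxygen of methoxy are absent from propyl. Nothing available explains this result.

Going by these compounds, whether an amine, a carboxylic acid or a longer chain such as hexyl on this aromatic carbon would separate from compound 3 stays open. So does whether propyl would give a similar step on the substituted aromatic ring of compound 2.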